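Removing the Hydroxy Group from Compound 3

The source may hold more compounds than are shown below. What is called first, only, known or untested is meant among the compounds shown, and "the series" means these compounds.

In a functional assay on the whole organism (stomach) for inhibition, with Rattus norvegicus as the target (a lower number here means that less compound is needed, a higher number that more compound is needed for the effect), compound 3 `Cc1cc(F)ccc1Nc1nc(N(C)c2ccccc2)c2cc(O)ccc2n1` gives 1.5 umol/kg. Compound 1 `CN(c1ccccc1)c1nc(N(C)c2ccccc2)c2ccccc2n1` gives 2.81 umol/kg, which lies within the usual scatter of compound 3. Compound 2 `COc1cccc2c(Nc3ccccc3C)nc(N)nc12` gives 7.11 umol/kg, clearly more than compound 3 and beyond that scatter.

Compound 4 `Cc1cc(F)ccc1Nc1nc(N(C)c2ccccc2)c2ccccc2n1` has hydrogen in place of hydroxy on an aromatic carbon. Within the data shown here, no measured pair shows this change alone, so the guide is indirect: compound 1 also has no hydroxy and gives 2.81 umol/kg. In this assay, the expected step is small, a 1.3-fold higher number from compound 3 to compound 4 (0.12 log units; within the scatter), towards a higher number and probably not beyond the scatter. The estimated value for compound 4 is 2 umol/kg, with an expected range of 0.7 umol/kg to 6 umol/kg.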

Compound 4, dose for half-maximal effect: 1.94 umol/kg
For compound 4 the middle estimate is 1.0-fold (0.01 log units) above the measured one, within the range that was stated.
By their numbers in this assay, from the lowest: compounds 3, 4 and 1 (each within the scatter of the next); then compound 2.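

In this assay, putting hydrogen in place of hydroxy gives a 1.3-fold higher number from compound 3 to compound 4 (0.11 log units; within the scatter), so the number for this shared core does not depend measurably on a hydroxy group at this aromatic carbon. Exchanging the other group, with (4-fluoro-2-methylphenyl)amino in place of methyl(phenyl)amino, gives a 1.4-fold lower number from compound 1 to compound 4 (0.16 log units; within the scatter), so that change also stays within the scatter. No measurement here explains either result. As far as these compounds go, whether an amine or a carboxylic acid on this carbon would also keep the number within the scatter remains open.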